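This account rests on a few compounds, and the source may have more. Where it says the series, first, only, none or still open, it means among the compounds named here.

For the measured compounds named here, in a physicochemical assay for lipophilicity (a higher number here means a more lipophilic compound, a lower number a more polar compound), compound 2, with the structure `CCOC(=O)/C=C(C)/C=C/CC(C)CCCC(C)(C)C`, gives 7.15, the highest of the two numbers known so far. Its nearest neighbour is compound 1, with the structure `CCOC(=O)/C=C(C)/C=C/CC(C)CCCC(C)(C)OC(C)=O`, which in this assay gives 5.57; the step of a number 1.58 log units higher from compound 1 to compound 2 (beyond the scatter) is beyond the scatter and large.

Compound 3, with the structure `CCOC(=O)/C=C(C)/C=C/CC(C)CCC(=O)C(C)C`, is still to be measured in this assay. It differs from compound 2 in one place: isopropylcarbonyl in place of neopentyl on a saturated chain carbon, four bonds along the chain from a double-bonded chain carbon. Read one bond further out, the change runs from 3,3-dimethylbutyl to (isopropylcarbonyl)methyl, a group with no hydrogen-bond acceptor giving way to one with a single hydrogen-bond acceptor.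

Going by the values given here, only one measured step bears on this, and only loosely: in the pair of compound 1 and compound 2 an oxygen-bearing group left and a carbon-only group entered, and the number rose by a number 1.58 log units higher from compound 1 to compound 2 (beyond the scatter). Here the direction is reversed, so a drop of similar order is expected, a number 1.60 log units lower from compound 2 to compound 3 (beyond the scatter). Compound 3 is therefore estimated at 5.55, within a range from 4.9 to 6.2.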

Compound 3, partition coefficient: 4.3
Compound 3: the middle estimate sits 1.25 log units above what was measured, outside the stated range (below it).
By their numbers in this assay, from the lowest: compound 3; then compound 1; then compound 2.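

In this assay the change at this position gives a number 2.85 log units lower from compound 2 to compound 3 (beyond the scatter), a large step that exceeds a number 1.58 log units higher from compound 1 to compound 2 (beyond the scatter) in size, though the two run in opposite directions. Neopentyl and isopropylcarbonyl each hold 5 heavy atoms, so the result shows that a large step can arise here with no change in heavy-atom count, the entering group differing by its carbonyl, with 1 hydrogen-bond acceptor where the leaving group has none. Nothing available accounts for the size of this step.

The compounds shown leave open whether the carbonyl itself goes with the step or whether any oxygen-bearing group on this saturated chain carbon would give a step of similar size, as a hydroxyl, a methoxy or an amide might show. They also leave open how a carbon-only replacement of a different shape, such as a longer chain or a cyclohexyl group, would compare with neopentyl at this place.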